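A few compounds are considered here, and "the series" means these few. Any claim that something is new, unique, unknown or untested is made for them only; others in the source may bear on it.

Measured compounds:
- compound 1 `CCCc1cc(N2CCCC2)c2cc(NC(=O)/C=C/c3ccc(C(F)(F)F)cc3)ccc2n1` gives 17 nM in an assay on isolated protein for displacement of a labelled ligand from melanin-concentrating hormone receptor 1 (Homo sapiens); on this read-out higher numbers stand for weaker inhibition and lower numbers for stronger inhibition
- compound 2 `CCCc1cc(N)c2cc(NC(=O)/C=C/c3ccc(Cl)cc3Cl)ccc2n1` gives 6.6 nM in this assay
- compound 3 `CCC(C)c1cc(N)c2cc(NC(=O)/C=C/c3ccc(C(F)(F)F)cc3)ccc2n1` gives 0.3 nM in this assay

Compound 2 holds the second highest number of the three: compound 1 sits at a higher number, beyond the scatter, and compound 3 at a much lower number, also beyond the scatter. Going by the values given here, no pair of measured compounds differs in a single place, so these gaps are read from the values alone. Compound 4 `CCCc1cc(N)c2cc(NC(=O)/C=C/c3ccccc3Cl)ccc2n1` is not yet measured. It differs from compound 2 as follows: hydrogen in place of chloro on an aromatic carbon. Nothing measured here removes a chloro group from a 2,4-dichlorophenyl, so the change is unanchored. The expectation is a step toward weaker inhibition in this assay, of size a 4.5-fold higher number from compound 2 to compound 4 (0.66 log units; beyond the scatter), somewhat beyond the scatter. Compound 4 is expected to give 30 nM, in the range 8 nM to 120 nM.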

Compound 4, half-maximal inhibitory concentration: 120 nM
Compound 4: middle estimate off by 4.0-fold (0.60 log units), on the low side; low and high end bracket the measured number.
By their numbers in this assay, from the lowest: compound 3; then compound 2; then compound 1; then compound 4.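

In this assay, going by these compounds alone, the change from 2,4-dichlorophenyl to 2-chlorophenyl gives an 18-fold higher number from compound 2 to compound 4 (1.26 log units; beyond the scatter) and is the first single-place comparison. A chloro group at this place, para to the large group, thus accounts for a large share of the inhibition seen with compound 2, which the earlier values alone could not show. Nothing available explains the size of this step. Open, from the compounds shown here alone, is whether a fluoro or methoxy group at this place would restore inhibition. Also open, going by these compounds, is what removing the other chloro group would do.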